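The source may hold more compounds than are shown below. What is called first, only, known or untested is meant among the compounds shown, and "the series" means these compounds.

Working notes on the series.

Compound 1 `Cc1c(-c2cc(Cl)cc(Cl)c2)c(C(=O)O)nn1-c1nc(-c2cnn(C)c2)c(SC(C)C)s1` and compound 3 `Cc1c(-c2cc(Cl)cc(Cl)c2)c(C(=O)O)nn1-c1nc(-c2ccncc2)c(SC(C)C)s1` carry the shared core with a dichlorophenyl and a carboxy group on the five-membered ring. In a functional assay on BJAB cells (Homo sapiens) for antiproliferative activity, with a stated time of 4 days (on this read-out higher numbers stand for an effect only at larger amounts of compound and lower numbers for an effect already at smaller amounts), compound 1 gives "not active" (no number reported) and compound 3 gives "not active" (no number reported); for neither is a number reported. Among the measured compounds shown here, compound 2 `Cc1cc(C)cc(-c2c(C)nn(-c3nc(-c4ccc(Cl)c(Cl)c4)c(SC(C)C)s3)c2C(=O)O)c1` is the one member with a numerical read-out: in this assay compound 2 gives 2700 nM. It therefore stands as the only quantified point, and the two other entries give nothing to compare it against beyond their lack of a number.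

Compound 4 `COc1cccc(-c2c(C)nn(-c3nc(-c4ccc(Cl)c(Cl)c4)c(SC(C)C)s3)c2C(=O)O)c1` is not yet measured. It differs from compound 2 in one place: 3-methoxyphenyl in place of 3,5-dimethylphenyl on an aromatic carbon. For the measured compounds named here, no measured pair shows what this exchange does, so the direction is open. The expected step in this assay is modest, from compound 2 to compound 4 a 1.5-fold higher number from compound 2 to compound 4 (0.17 log units; within the scatter), which is near the usual scatter and leans slightly toward a weaker effect. Compound 4 is expected to give 4000 nM in this assay, with a range from 1200 nM to 13000 nM.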

Compound 4, half-maximal effective concentration: 14000 nM
Compound 4: middle estimate off by 3.5-fold (0.54 log units), on the low side, and the stated range ends below it.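

In this assay, 3-methoxyphenyl in place of 3,5-dimethylphenyl gives a 5.2-fold higher number from compound 2 to compound 4 (0.71 log units; beyond the scatter), so the effect appears only at larger amounts of compound. Among the compounds shown here, this is the first reading of this position, on the aromatic carbon next to the ring atom that bears a carboxy group, and it shows that the aryl group here matters even though both groups have 8 heavy atoms and one six-membered aromatic ring of carbon only. Nothing at hand explains the shift.

For the compounds shown here, the single step changes the substituents on the aryl ring together, so the loss of the two methyl groups and the entry of the methoxy group cannot be told apart. As far as these compounds go, a 3-methylphenyl or 3,5-dimethoxyphenyl group at this place would separate the two, and how an amine on the aryl ring would behave stays open.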